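The source may report more compounds than this note shows. Statements on the series, on what has been measured and on what is new or still open speak of the compounds shown alone.

Compound 1 `CCc1ccc(Nc2cc(NC(=O)Nc3c(Cl)cccc3Cl)ncn2)cc1`: 70.1%
Compound 2 `COc1ccc(OC)c(Nc2cc(NC(=O)Nc3c(Cl)cccc3Cl)ncn2)c1`: 95%
Compound 3 `Cc1ccc(Nc2cc(NC(=O)Nc3c(Cl)cccc3Cl)ncn2)cc1F`: 92%

In a functional assay on PC-9 cells (Homo sapiens) for inhibition, read by MTT assay, with a stated time of 48 h, tested at 10 uM (on this read-out lower numbers stand for less inhibition and higher numbers for more inhibition at the one concentration tested (going by the name of the read-out)), compound 2 gives the highest of the three numbers, though compound 3 lies within the scatter of it and only compound 1 falls clearly lower. Compound 4 `COc1ccc(C(F)(F)F)cc1Nc1cc(NC(=O)Nc2c(Cl)cccc2Cl)ncn1` changes one group on the ring that hangs from the nitrogen: trifluoromethyl in place of methoxy on an aromatic carbon. Within the data shown here, the single measured step, a number 21.9 percentage points higher from compound 1 to compound 3 (beyond the scatter), swaps groups on that same ring but not methoxy for trifluoromethyl, so it bears only loosely on this change. Because compound 2 already gives 95%, little room remains upward, and a small drop is expected for compound 4, a number 10 percentage points lower from compound 2 to compound 4 (within the scatter). Compound 4 is therefore estimated at 85%, between 60% and 98%.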

Compound 4, a percentage reported as inhibition, at one concentration (the size of the read-out at that concentration, not a potency): 89%
Compound 4: middle estimate off by 4 percentage points, on the low side; the range from low to high includes it.
By their numbers in this assay, from the lowest: compound 1; then compounds 4, 3 and 2 (each within the scatter of the next).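

In this assay, trifluoromethyl in place of methoxy on this aromatic carbon gives a number 6 percentage points lower from compound 2 to compound 4 (within the scatter) and so leaves the reading unchanged within the scatter. The hydrogen-bond acceptor that leaves with methoxy is therefore not required at this position for this read-out at the one concentration tested. Nothing available explains why the two groups read alike.

Going by these compounds, whether an amine or a carboxylic acid on this carbon would hold the number stays open. Compounds 2, 3 and 4 cannot be ranked from these readings.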